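The compounds below may be only part of what the source reports. "The series", "measured", "known", "first", "only" and "open" are said of these compounds alone.

The study compares three measured sulfonamides in a functional assay on HepG2 cells (Homo sapiens) for cytotoxicity, read by sulforhodamine B assay, with a stated time of 48 h (a lower number here means a stronger inhibitor, a higher number a weaker inhibitor), and then asks what a fourth, not yet measured, may give. Compound 1 `C/C(=N\n1c(N)cc(N)c(C#N)c1=O)c1ccc(NS(=O)(=O)c2ccc(C)cc2)cc1` gives 37000 nM in this assay. Compound 3 `C/C(=N\NC(=O)CC#N)c1ccc(NS(=O)(=O)c2ccc(C)cc2)cc1` gives 26000 nM in this assay. Compound 2 `Cc1ccc(S(=O)(=O)Nc2ccc(-c3cc(-c4ccc([N+](=O)[O-])cc4)[nH]n3)cc2)cc1` gives 44800 nM in this assay; its number is the highest of the three shown, but the gaps to compound 1 and to compound 3 are both within the usual scatter, so the three compounds cannot be told apart on these data.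

Compound 4 `Cc1ccc(S(=O)(=O)Nc2ccc(-c3cc(-c4ccc([N+](=O)[O-])cc4)n(C(=S)NN)n3)cc2)cc1` is built from compound 2 by the change (a group of 4 heavy atoms (1 carbon, 2 nitrogen, 1 sulfur; no ring) in place of a hydrogen atom, on an aromatic nitrogen). Going by the values given here, no pair of measured compounds differing in one place is available, so there is no measured step to guide the size of this change. All three measured values are weak and alike, and nothing among them speaks for a large move in either direction.

On that basis the step from compound 2 to compound 4 is expected to be small, a 1.4-fold lower number from compound 2 to compound 4 (0.15 log units; within the scatter), and not clearly beyond the scatter. Compound 4 is therefore estimated at 32000 nM in this assay, within a range from 10000 nM to 100000 nM.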

Compound 4, half-maximal inhibitory concentration: 45300 nM
The estimate for compound 4 lay 1.4-fold (0.15 log units) below the measured number; measured number inside the range.
By their numbers in this assay, from the lowest: compounds 3, 1, 2 and 4 (each within the scatter of the next).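

In this assay, going by these compounds alone, the one step measured at this position, on an aromatic nitrogen of the five-membered aromatic ring, is a 1.0-fold higher number from compound 2 to compound 4 (0.00 log units; within the scatter), and it lies within the scatter. For this single change, the hydrogen atom on that nitrogen can be replaced by a group of 4 heavy atoms (1 carbon, 2 nitrogen, 1 sulfur; no ring) without any difference that can be read in this assay, even though the position is next to the ring atom that bears a 4-nitrophenyl group. No measurement at hand bears on why the two compounds cannot be told apart.

The compounds shown leave open whether a methyl group, an acetyl group or a longer chain ending in an amine on that same nitrogen would give a number that stands beyond the scatter, as this one group does not. Within the data shown here, they also leave open whether a 4-aminophenyl group or a plain phenyl group in place of the 4-nitrophenyl group would give a number different from the one these two compounds share within the scatter.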